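The compounds below may be only part of what the source reports. "The series", "measured", "known", "first", "only" and "open" are said of these compounds alone.

Measured so far:
- compound 1, `Cc1ccc(NC(=O)N[C@H]2CC[C@H](Oc3ccc(F)cc3)CC2)cc1`
- compound 2, `O=C(Nc1ccccc1)N[C@H]1CC[C@H](Oc2ccc(F)cc2)CC1`

In a functional assay on CRL2813 cells (Homo sapiens) for cytotoxicity, read by sulforhodamine B assay, with a stated time of 5 days (a higher number here means a weaker inhibitor, a lower number a stronger inhibitor), compound 1 gives > 20000 nM, which is a limit of the assay rather than a number. In this assay compound 2 gives 20000 nM. Within the data shown here, the change a number no higher from compound 1 to compound 2 (the limit leaves the size open) is the only measured step, and its size cannot be read because of the limit of > 20000 nM in this assay, at which 1 of the 2 values shown sits. Compound 2 therefore carries the only number shown, and the other value is a limit.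

Compound 3, `O=C(Nc1cccc([N+](=O)[O-])c1)N[C@H]1CC[C@H](Oc2ccc(F)cc2)CC1`, differs from compound 2 in one place: nitro in place of hydrogen on an aromatic carbon. Among the measured compounds shown here, the only measured step swapped a methyl for hydrogen on an aromatic carbon, so no measured step matches a nitro entering, and the one step that exists has no readable size. With nothing pointing either way, no step beyond the scatter is expected. Compound 3 is estimated at 15000 nM, between 4000 nM and 40000 nM, which means an expected step of a 1.3-fold lower number from compound 2 to compound 3 (0.12 log units; within the scatter).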

Compound 3, half-maximal inhibitory concentration: 6700 nM
Compound 3: the middle estimate sits 2.2-fold (0.35 log units) above what was measured, and the stated range covers the measured number.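

In this assay, among these compounds, this is the first step whose size can be read: a nitro group on the phenyl ring, giving the 3-nitrophenyl, produces a 3.0-fold lower number from compound 2 to compound 3 (0.47 log units; beyond the scatter). So this aromatic carbon can carry a group that moves the number beyond the scatter, which the methyl of compound 1 could not show. Set against the 4-methylphenyl, the 3-nitrophenyl gives an at least 2.9-fold lower number from compound 1 to compound 3 (0.47 log units; beyond the scatter), and this size is only a minimum because one end of the step is a limit: the limit of > 20000 nM in this assay, at which 1 of the 3 values shown sits.

As far as these compounds go, with a single nitro group, it remains open whether the step belongs to nitro itself or would also come with an amine, a nitrile or a carboxylic acid on that ring. From the compounds shown here alone, it is equally open whether the step depends on where on the ring the group sits.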